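A few compounds are considered here, and "the series" means these few. Any claim that something is new, unique, unknown or untested is made for them only; others in the source may bear on it.

Compound 1 `Oc1ccc(-c2cc(-c3ccsc3)cc(-c3ccc(O)cc3)n2)cc1` and compound 2 `Oc1ccc(-c2cc(-c3ccoc3)cc(-c3ccc(O)cc3)n2)cc1` share one core carrying two 4-hydroxyphenyl groups and differ in a single group. In a functional assay on HCT-15 cells (Homo sapiens) for cytotoxicity, read by CCK-8 assay (a lower number here means a stronger inhibitor, a higher number a weaker inhibitor), compound 1 gives 1040 nM. In this assay compound 2 gives 1530 nM. Between them the step is a 1.5-fold higher number from compound 1 to compound 2 (0.17 log units; within the scatter). Compound 3 `Oc1ccc(-c2cc(-c3cccnc3)cc(-c3cccc(O)c3)n2)cc1` carries a pyridin-3-yl group and one 3-hydroxyphenyl group. In this assay, among the measured compounds shown here, compound 3 gives > 50000 nM, which is a limit of the assay rather than a number. the limit of > 50000 nM in this assay, at which 1 of the 3 values shown sits, is all that is known of compound 3 in this assay, so no measured step leads away from it. Compound 4 `Oc1ccc(-c2cc(-c3cccnc3)cc(-c3ccc(O)cc3)n2)cc1` differs from compound 3 by 4-hydroxyphenyl in place of 3-hydroxyphenyl on an aromatic carbon; with this change compound 4 carries the same pair of 4-hydroxyphenyl groups as compound 1 and compound 2. For the measured compounds named here, the only measured step, from compound 1 to compound 2, concerns another group and is within the scatter, so it gives no direction here. The expectation therefore rests on compound 1 giving 1040 nM and on compound 2 giving 1530 nM. Compound 4 is expected to give 1500 nM in this assay, with a range from 500 nM to 5000 nM. The estimated step is an at least 33-fold lower number from compound 3 to compound 4 (1.52 log units; beyond the scatter).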

Compound 4, half-maximal inhibitory concentration: 840 nM
For compound 4 the middle estimate is 1.8-fold (0.25 log units) above the measured one; low and high end bracket the measured number.
By their numbers in this assay, from the lowest: compounds 4, 1 and 2 (each within the scatter of the next). At a limit, above all of these: compound 3.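

In this assay, among the compounds shown here, the swap of 4-hydroxyphenyl for 3-hydroxyphenyl, on the aromatic carbon next to the ring nitrogen, gives an at least 59-fold lower number from compound 3 to compound 4 (1.77 log units; beyond the scatter), so the place of the hydroxyl on this phenyl ring matters far more than anything the earlier compounds showed. The other group, by contrast, shows no clear effect with the pair of 4-hydroxyphenyl groups in place: pyridin-3-yl for furan-3-yl gives a 1.8-fold lower number from compound 2 to compound 4 (0.26 log units; within the scatter), and pyridin-3-yl for thiophen-3-yl gives a 1.2-fold lower number from compound 1 to compound 4 (0.09 log units; within the scatter). The value of compound 3 is a limit and not a number, so the first step is known only as a bound: the limit of > 50000 nM in this assay, at which 1 of the 4 values shown sits.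

Going by these compounds, the 3-hydroxyphenyl group appears here only alongside pyridin-3-yl, so its effect alongside thiophen-3-yl or furan-3-yl remains open. Also open, on these data alone, is whether a 4-methoxyphenyl or 4-aminophenyl group could stand in place of 4-hydroxyphenyl at this position.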